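The compounds below may be only part of what the source reports. "The series", "measured", "known", "first", "only" and "open" are said of these compounds alone.

Measured in a functional assay on PC-3 cells (Homo sapiens) for antiproliferative activity, read by MTT assay, tested at 1 uM; on this read-out higher numbers stand for a stronger effect at the one concentration tested and lower numbers for a weaker effect:
compound 1 `COc1cc(C2=NN(C(C)=O)C(c3c(Cl)cccc3Cl)O2)cc(OC)c1OC` gives 5.1% in this assay
compound 2 `COc1cc(C2=NN(C(C)=O)C(c3ccccc3C(F)(F)F)O2)cc(OC)c1OC` gives -11% in this assay
compound 3 `COc1cc(C2=NN(C(C)=O)C(c3cccc(F)c3)O2)cc(OC)c1OC` gives 16.5% in this assay

Compound 3 holds the highest of the three numbers: a number 11.4 percentage points higher from compound 1 to compound 3 (beyond the scatter) and a number 27.5 percentage points higher from compound 2 to compound 3 (beyond the scatter) are both beyond the scatter, so compound 3 stands clearly above compound 1 and compound 2 in this assay at the single concentration tested. Compound 4 `COc1cc(C2=NN(C(C)=O)C(c3ccc(F)c(F)c3)O2)cc(OC)c1OC` is not yet measured; it differs from compound 3 by fluoro in place of hydrogen on an aromatic carbon on the phenyl ring that compound 3 carries. For the measured compounds named here, no measured step bears directly on this change: a number 16.1 percentage points lower from compound 1 to compound 2 (beyond the scatter) and the other two steps exchange whole aryl groups rather than adding one fluoro to an otherwise kept ring. Without a guiding step, the change is expected to be small, a number 1.5 percentage points higher from compound 3 to compound 4 (within the scatter) within the scatter. Compound 4 is estimated at 18% with a range from 5% to 32% in this assay.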

Compound 4, a percentage reported as inhibition, at one concentration (the size of the read-out at that concentration, not a potency): 35.5%
Estimate against measurement, compound 4: 17.5 percentage points below; the measured number lies above the stated range.
By their numbers in this assay, from the lowest: compound 2; then compound 1; then compound 3; then compound 4.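

In this assay, fluoro in place of hydrogen, para to a large group and ortho to a fluoro group, gives a number 19 percentage points higher from compound 3 to compound 4 (beyond the scatter), so this ring position responds to a one-atom change. The whole-aryl exchanges, a number 30.4 percentage points higher from compound 1 to compound 4 (beyond the scatter) and a number 46.5 percentage points higher from compound 2 to compound 4 (beyond the scatter), place 3,4-difluorophenyl clearly above the other three aryl groups. Nothing at hand accounts for these steps.

From the compounds shown here alone, whether 4-fluorophenyl alone would match 3,4-difluorophenyl remains open. So does the response at this position to chloro, methoxy or an amine.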